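Swapping the urea aryl group toward a lone trifluoromethyl

The compounds below may be only part of what the source reports. "The series", "measured", "known", "first", "only" and "open" are said of these compounds alone.

Of the compounds shown here, three sharing one core have been tested in a functional assay on KM12 cells (Homo sapiens) for inhibition, read by sulforhodamine B assay, with a stated time of 48 h, tested at 100 uM; a lower number here means a stronger effect, a higher number a weaker effect of the compound at the concentration tested. Compound 1 `COc1cc(Cl)cc(-c2nn(-c3cccc(NC(=O)Nc4ccc(Cl)c(C(F)(F)F)c4)c3)cc2-c2ccncc2)c1` gives -70%, compound 2 `COc1cc(Cl)cc(-c2nn(-c3cccc(NC(=O)Nc4cc(C(F)(F)F)cc(C(F)(F)F)c4)c3)cc2-c2ccncc2)c1` gives -83%, and compound 3 `COc1cc(Cl)cc(-c2nn(-c3cccc(NC(=O)Nc4ccc(Cl)c(Cl)c4)c3)cc2-c2ccncc2)c1` gives -17%, the highest of the three numbers and therefore the weakest effect among them. Compound 4 `COc1cc(Cl)cc(-c2nn(-c3cccc(NC(=O)Nc4cccc(C(F)(F)F)c4)c3)cc2-c2ccncc2)c1` is the compound still to be measured. Among the measured compounds shown here, the one measured step that bears on its case is a number 53 percentage points higher from compound 1 to compound 3 (beyond the scatter), a large move in the direction of weaker effect. The change now made is 3-(trifluoromethyl)phenyl in place of 3,4-dichlorophenyl on an amide-type nitrogen. Because a number 53 percentage points higher from compound 1 to compound 3 (beyond the scatter) showed a large move toward weaker effect and the change to compound 4 reverses much of that, compound 4 is expected to move back toward a stronger effect by a number 28 percentage points lower from compound 3 to compound 4 (beyond the scatter) in this assay. The estimate for compound 4 is -45%, within -80% to -10%.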

Compound 4, a percentage reported as activity, at one concentration (the size of the read-out at that concentration, not a potency): -48%
Compound 4: middle estimate off by 3 percentage points, on the high side; the range from low to high includes it.
By their numbers in this assay, from the lowest: compound 2; then compound 1; then compound 4; then compound 3.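

In this assay, the step of a number 31 percentage points lower from compound 3 to compound 4 (beyond the scatter) shows that 3-(trifluoromethyl)phenyl outdoes 3,4-dichlorophenyl on this amide-type nitrogen. Yet a lone trifluoromethyl does not give the full effect: a number 35 percentage points higher from compound 2 to compound 4 (beyond the scatter) comes with hydrogen in place of trifluoromethyl, and a number 22 percentage points higher from compound 1 to compound 4 (beyond the scatter) comes with hydrogen in place of chloro. Nothing measured here explains these moves.

Still open, as far as these compounds go, is whether a nitrile or a methyl group could stand in for the second trifluoromethyl or the chloro and keep the stronger effect.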